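The source may hold more compounds than are shown below. What is called first, only, known or untested is meant among the compounds shown, and "the series" means these compounds.

Compound 1 `CC(C)N1CCC(Oc2ccc(C(=O)Nc3ccc(NC(=O)Nc4cc(C(C)(C)C)on4)cc3)nc2)CC1` gives the highest of the three numbers in an in vivo ADME assay on the whole organism (plasma, strain Sprague-Dawley) for pharmacokinetics, with Rattus norvegicus as the target, read by LC-MS, at a dose of 10 mg/kg by the oral route (a higher number here means that a larger share of the oral dose reaches the circulation, a lower number that a smaller share of the oral dose reaches the circulation), namely 17.5%. Among the measured compounds shown here, compound 3 `Cc1ccnc(C(=O)Nc2ccc(NC(=O)Nc3cc(C(C)(C)C)on3)cc2)c1` gives 4% in this assay, and compound 2 `CC(C)(C)c1cc(NC(=O)Nc2ccc(NC(=O)c3cc(OC4CCNCC4)ccn3)cc2)no1` gives 3%; the only measured step, a number 1 percentage points higher from compound 2 to compound 3 (within the scatter), concerns a change elsewhere on the shared core and does not bear on the present question. Compound 4 `CC(C)(C)c1cc(NC(=O)Nc2ccc(NC(=O)c3ccc(OC4CCN(C5CC5)CC4)cn3)cc2)no1` differs from compound 1 in one place: cyclopropyl in place of isopropyl on an amine nitrogen in a ring. For the measured compounds named here, no measured pair tracks this change; the values of compound 2 and compound 1 show an unsubstituted ring nitrogen beside a substituted one, but they differ in more than that place. Compound 4 is therefore expected to stay near compound 1, with a step of a number 2.5 percentage points lower from compound 1 to compound 4 (within the scatter) and an estimate of 15%, ranging from 5% to 30%.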

Compound 4, oral bioavailability: 36%
The estimate for compound 4 lay 21 percentage points below the measured number; measured number above the stated range.
By their numbers in this assay, from the lowest: compounds 2 and 3 (each within the scatter of the next); then compound 1; then compound 4.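

In this assay, the group on the amine nitrogen in a ring proves able to shift the reading: cyclopropyl in place of isopropyl gives a number 18.5 percentage points higher from compound 1 to compound 4 (beyond the scatter) and is the first step shown at this position. Both groups hold 3 heavy atoms, all carbon, so the step accompanies the closing of a three-membered ring, with that count unchanged.

On these data alone, whether a cyclobutyl or an acetyl group on the same nitrogen would go with a higher or lower number stays open. The reason for the step also stays open, as no available measurement bears on it.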